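The source may report more compounds than this note shows. Statements on the series, on what has been measured and on what is new or still open speak of the compounds shown alone.

Of the compounds shown here, three built on a shared core have been tested in an ADME assay on microsomes from liver (Mus musculus) for metabolic stability, using NADPH, with a stated time of 10 min; a lower number here means that less of the compound is left, a higher number that more of the compound is left: compound 1 (`NC/C=C/CN(C[C@H]1Cc2ncccc2CN1)[C@H]1CCCc2cccnc21`), compound 2 (`CCN(CC)CCCCN(C[C@H]1Cc2ncccc2CN1)[C@H]1CCCc2cccnc21`) and compound 3 (`CN(CCCCN(C[C@H]1Cc2ncccc2CN1)[C@H]1CCCc2cccnc21)C1CCOCC1`). Compound 3 stands highest of the three at 51%, while compound 1 gives 37% and compound 2 gives 1%.

Compound 4 (`c1cnc2c(c1)CN[C@@H](CN(CCCCNC1COC1)[C@H]1CCCc3cccnc31)C2`), not yet measured, differs from compound 3 in one group: (oxetan-3-yl)amino in place of methyl(oxan-4-yl)amino on a saturated chain carbon, four bonds along the chain from an amine nitrogen. In words, (oxetan-3-yl)amino stands in place of methyl(oxan-4-yl)amino on a saturated chain carbon, four bonds along the chain from an amine nitrogen.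

The most relevant evidence comes from this same place, where methyl(oxan-4-yl)amino in place of diethylamino gave a large step, a number 50 percentage points higher from compound 2 to compound 3 (beyond the scatter). The other two steps, a number 14 percentage points higher from compound 1 to compound 3 (beyond the scatter), which is modest, and a number 36 percentage points lower from compound 1 to compound 2 (beyond the scatter), which is large, exchange a longer stretch of the chain and bear on the change less directly. Compound 4 keeps a non-aromatic ring with 1 hetero atom, as compound 3 does, whereas the diethylamino group of compound 2 has none. Among the compounds with values here, no measured compound carries the four-membered ring, so the uncertainty is wide. In this assay, no step beyond the scatter is expected. The estimated step is a number 6 percentage points lower from compound 3 to compound 4 (within the scatter). For compound 4 the estimate is 45%, with an expected range from 20% to 72%.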

Compound 4, percent of the compound remaining: 41%
The estimate for compound 4 lay 4 percentage points above the measured number; low and high end bracket the measured number.
By their numbers in this assay, from the lowest: compound 2; then compounds 1, 4 and 3 (each within the scatter of the next, the first and the last beyond it).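

In this assay, the four-membered ring fits this position as well as the six-membered one: (oxetan-3-yl)amino in place of methyl(oxan-4-yl)amino leaves the number within the scatter (a number 10 percentage points lower from compound 3 to compound 4 (within the scatter)), even though the new group also brings a hydrogen-bond donor. The low number of compound 2 now stands apart from two ring-bearing groups rather than one (a number 40 percentage points higher from compound 2 to compound 4 (beyond the scatter)), yet a ring is not required, since compound 1 has no ring in its group and still lies within the scatter of the oxetane compound (a number 4 percentage points higher from compound 1 to compound 4 (within the scatter)). No measurement offered here explains why these groups give these numbers.

Compounds 3 and 4 differ in ring size and in the methyl on the amine nitrogen at once, so methyl(oxetan-3-yl)amino would be needed to tell these two changes apart. Going by these compounds, whether the ring oxygen matters also stays open, and cyclobutylamino, which has a four-membered ring of carbon alone, would address that question at this position.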